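Swapping the basic tail of a bradykinin B1 antagonist

A few compounds are considered here, and "the series" means these few. Any claim that something is new, unique, unknown or untested is made for them only; others in the source may bear on it.

Three compounds have numbers in an assay on HEK293 cells for displacement of a labelled ligand from B1 bradykinin receptor (Homo sapiens), read by scintillation counting; a higher number here means a weaker inhibitor, a lower number a stronger inhibitor. Compound 1 `CCN(CC)CCN1CCN(C(=O)COCCN(C)S(=O)(=O)c2c(C)cc(OC)cc2C)CC1` gives 10 nM, the highest of the three. Compound 3 `COc1cc(C)c(S(=O)(=O)N(C)CCOCC(=O)N2CCC(N3CCN(C(C)C)CC3)CC2)c(C)c1` gives 3.8 nM and sits nearest to compound 1, yet the gap between them is beyond the scatter. Compound 2 `Cc1c(Cl)ccc(S(=O)(=O)N(C)CCOCC(=O)N(C)Cc2ccc(C3=NCCN3)cc2)c1Cl` gives 2.1 nM and lies furthest from compound 1, again beyond the scatter. Compound 1 is thus the weakest inhibitor among the three.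

Compound 4 `COc1cc(C)c(S(=O)(=O)N(C)CCOCC(=O)N2CCN([C@@H]3CN4CCC3CC4)CC2)c(C)c1` has not been measured. It differs from compound 1 in one place: a group of 8 heavy atoms (7 carbon, 1 nitrogen; 2 six-membered non-aromatic rings with 1 hetero atom each) in place of a group of 7 heavy atoms (6 carbon, 1 nitrogen; no ring), on an amine nitrogen in a ring. Among the measured compounds shown here, no pair of measured compounds shows this particular change, so there is no measured step to rest on; compound 3, which carries a different cyclic amine on its shared core, gives 3.8 nM, a number that falls below compound 1.

Compound 4 is therefore expected to give a somewhat lower number than compound 1, a step of a 2.0-fold lower number from compound 1 to compound 4 (0.30 log units; within the scatter), though this expectation is uncertain. The estimate for compound 4 in this assay is 5 nM, with a range from 1.5 nM to 20 nM.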

Compound 4, inhibition constant: 5.6 nM
Estimate against measurement, compound 4: 1.1-fold (0.05 log units) below; the range from low to high includes it.
By their numbers in this assay, from the lowest: compounds 2, 3, 4 and 1 (each within the scatter of the next, the first and the last beyond it).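

On the amine nitrogen in the six-membered ring of the shared core, exchanging the open 2-(diethylamino)ethyl chain for a group of two six-membered non-aromatic rings with one defined stereocentre gives a 1.8-fold lower number from compound 1 to compound 4 (0.25 log units; within the scatter) in this assay and so leaves the number within the scatter. Among the compounds shown here, this is the first measured step at this position, and it shows that the chain need not stay open for the number to hold at this level. No measurement shown here bears on why the two groups read alike.

Going by these compounds, whether a plain methyl or a single-ring 1-methylpiperidin-4-yl group on the same nitrogen would also hold the number remains open. So does how the mirror-image form of the entering group would read in this assay on this core.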